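Pyrrolidine substituent swap in a dichlorophenyl chemokine antagonist series

A few compounds are considered here, and "the series" means these few. Any claim that something is new, unique, unknown or untested is made for them only; others in the source may bear on it.

Measured so far:
Compound 1, `Cc1nn([C@H](C)c2ccc(Cl)cc2Cl)c2nc(N3CC[C@H](N4CCC[C@H]4C(N)=O)[C@H](C)C3)cnc12`: "not determined" (no result reported)
Compound 2, `C[C@@H]1CC(c2cnc3c(C#N)nn([C@H](C)c4ccc(Cl)cc4Cl)c3n2)=CC[C@@H]1N1CCC[C@H]1C(C)(C)O`: 1200 nM
Compound 3, `Cc1nn([C@H](C)c2ccc(Cl)cc2Cl)c2nc(N3CC[C@H](N4CCC[C@H]4C(=O)O)[C@H](C)C3)cnc12`: "not determined" (no result reported)

Compound 1 stands without a number in an assay on CCRF-CEM cells for antagonist activity at C-C chemokine receptor type 4 (Homo sapiens), read by CellTiter-Glo, with stated times of 30 min and 60 min, in the presence of a further agent that is not named here; a lower number here means a stronger inhibitor, a higher number a weaker inhibitor; compound 3 likewise has none. The only figure in this assay belongs to compound 2, which gives 1200 nM and shares neither the saturated six-membered amine nor the methyl on the core with compound 1, so it serves only as a loose anchor.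

Compound 4, `Cc1nn([C@H](C)c2ccc(Cl)cc2Cl)c2nc(N3CC[C@H](N4CCC[C@H]4CCC#N)[C@H](C)C3)cnc12`, follows from compound 1 by one change: 2-cyanoethyl in place of carbamoyl on a saturated ring carbon. For the measured compounds named here, no measured pair matches this change, and compound 1 itself has no value, so no direction can be read for the step. A moderate shift, within or just beyond the usual scatter, is expected in this assay. Compound 4 is estimated at 600 nM, in the range 60 nM to 6000 nM.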

Compound 4, half-maximal inhibitory concentration: 865 nM
For compound 4 the middle estimate is 1.4-fold (0.16 log units) below the measured one, and the stated range covers the measured number.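

For the compounds shown here, compound 1 holds no number in this assay so no step to compound 4 can be read. The compounds shown leave open how 2-carbamoylpyrrolidin-1-yl and 2-(2-cyanoethyl)pyrrolidin-1-yl compare on the shared core. No evidence bears on this result.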